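The compounds below may be only part of what the source reports. "The series", "measured", "known", "first", "only" and "open" are said of these compounds alone.

Three compounds that share one core and differ only on an oxygen next to a carbonyl group have been tested in a functional assay on the whole organism (strain Sprague-Dawley CD) for inhibition, with Rattus norvegicus as the target, read by paw edema, at a dose of 30 mg/kg by the oral route; on this read-out lower numbers stand for a weaker effect and higher numbers for a stronger effect at the one dose given. In that assay compound 1 `CC(C)OC(=O)C(=O)Nc1cccccc1=O` gives 63%, compound 2 `CCCCCOC(=O)C(=O)Nc1cccccc1=O` gives 12%, and compound 3 `CCOC(=O)COC(=O)C(=O)Nc1cccccc1=O` gives 31%. Compound 3 thus stands second highest of the three: the step of a number 32 percentage points lower from compound 1 to compound 3 (beyond the scatter) is large, while the step of a number 19 percentage points higher from compound 2 to compound 3 (beyond the scatter) is modest. Compound 4 `O=C(Nc1cccccc1=O)C(=O)Oc1ccccc1` has not been measured; against compound 3 it shows (phenyl in place of (ethoxycarbonyl)methyl on an oxygen next to a carbonyl group). The steps of a number 51 percentage points lower from compound 1 to compound 2 (beyond the scatter) and a number 32 percentage points lower from compound 1 to compound 3 (beyond the scatter) show that exchanging the group on this oxygen can shift the read-out widely, and no phenyl has been tried here. A step of uncertain direction is therefore expected, a number 4 percentage points higher from compound 3 to compound 4 (within the scatter). Compound 4 is estimated at 35%, within a range from 10% to 65%.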

Compound 4, a percentage reported as inhibition, in the whole organism at one dose (the size of the read-out at that dose, not a potency): 31%
Estimate against measurement, compound 4: 4 percentage points above; the measured number falls inside the stated range.
By their numbers in this assay, from the lowest: compound 2; then compounds 3 and 4 (each within the scatter of the next); then compound 1.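

On this oxygen, exchanging the open chain (ethoxycarbonyl)methyl for the aromatic ring of phenyl gives no change at the digits printed from compound 3 to compound 4 (within the scatter), so this assay does not separate these two groups, although one has two hydrogen-bond acceptors and the other none. Against pentyl, phenyl gives a number 19 percentage points higher from compound 2 to compound 4 (beyond the scatter), and against isopropyl it gives a number 32 percentage points lower from compound 1 to compound 4 (beyond the scatter). Nothing available explains these steps.

From the compounds shown here alone, whether a cyclohexyl or benzyl group on this oxygen would come nearer to isopropyl or stay level with phenyl remains open.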